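Swapping Methoxy for Methyl on a Thiosemicarbazone

A few compounds are considered here, and "the series" means these few. Any claim that something is new, unique, unknown or untested is made for them only; others in the source may bear on it.

Compound 1, `COc1ccccc1NC(=S)N/N=C/c1ccc2ccccc2n1`, was tested in a functional assay on SGC-7901 cells (Homo sapiens) for antiproliferative activity, read by sulforhodamine B assay, with a stated time of 72 h; on this read-out higher numbers stand for weaker inhibition and lower numbers for stronger inhibition. In this assay compound 1 gives only a limit, > 100000 nM. Two related compounds share this outcome. Compound 2, `NC(=S)N/N=C/c1cnc2ccccc2n1`, also reaches only the limit > 100000 nM in this assay. Compound 3, `Cc1ccc(NC(=O)N/N=C/c2ccc3ccccc3n2)cc1`, likewise shows only the limit > 100000 nM in this assay. Compound 1 therefore stands at the limit of > 100000 nM in this assay, at which 3 of the 3 values shown sit, and nothing in the numbers shown separates it from the other two.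

Compound 4, `Cc1ccccc1NC(=S)N/N=C/c1ccc2ccccc2n1`, has not yet been measured. It differs from compound 1 by methyl in place of methoxy on an aromatic carbon. Within the data shown here, no pair of measured compounds differs in a single place, so the size of such a change cannot be read from the data. Because compound 1 sits at the limit of > 100000 nM in this assay, at which 3 of the 3 values shown sit, compound 4 is expected to remain at the limit as well, with a step of a number no higher from compound 1 to compound 4 (the limit leaves the size open) that is no larger than the usual scatter. Compound 4 is estimated at 100000 nM, within 30000 nM to 300000 nM in this assay.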

Compound 4, half-maximal inhibitory concentration: > 100000 nM
Compound 4 gave a limit, no number (the forecaster's own chance of this, stated with the estimate: 80%); the middle value sits exactly at the limit.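

No step can be read between compound 1 and compound 4, because each gives only a limit and not a number: the limit of > 100000 nM in this assay, at which 4 of the 4 values shown sit.

What stays open is whether methyl in place of methoxy changes anything in this assay, and what true value any of these compounds has.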